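Removing a dodecyl group from compound 2

This account rests on a few compounds, and the source may have more. Where it says the series, first, only, none or still open, it means among the compounds named here.

compound 1 `C/C=C1/[C@H](O[C@@H]2O[C@H](CO)[C@@H](O)[C@H](O)[C@H]2O)OC=C(C(=O)OC)[C@H]1CC(=O)OCCCCCCCCCCCCCCC` gives 2700 nM
compound 2 `C/C=C1/[C@H](O[C@@H]2O[C@H](COC(C)=O)[C@@H](OC(C)=O)[C@H](OC(C)=O)[C@H]2OC(C)=O)OC=C(C(=O)OC)[C@H]1CC(=O)OCCCCCCCCCCCCCCC` gives 17000 nM
compound 3 `C/C=C1/[C@H](O[C@@H]2O[C@H](CO)[C@@H](O)[C@H](O)[C@H]2O)OC=C(C(=O)OC)[C@H]1CC(=O)OCCC1CCCCC1` gives 5600 nM

All three values come from a functional assay on HeLa cells (Homo sapiens) for antiproliferative activity, read by MTT assay, with a stated time of 72 h (a lower number here means a stronger inhibitor, a higher number a weaker inhibitor), and were obtained on the same cells. Compound 2, at 17000 nM in this test, has the highest number of the three and is the weakest inhibitor among them, with both gaps lying beyond the usual scatter. Compound 3 at 5600 nM is its nearest neighbour, and compound 1 at 2700 nM is the furthest from it.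

Compound 4 `C/C=C1/[C@H](O[C@@H]2O[C@H](COC(C)=O)[C@@H](OC(C)=O)[C@H](OC(C)=O)[C@H]2OC(C)=O)OC=C(C(=O)OC)[C@H]1CC(=O)OCCC` has not yet been measured. It differs from compound 2 in one place, with hydrogen in place of dodecyl on a saturated chain carbon, three bonds along the chain from an oxygen next to a carbonyl group. Within the data shown here, no two measured compounds differ in only one place, so the data offer no direct guide to this change. The expectation therefore starts from compound 2 at 17000 nM as its anchor and stays deliberately wide. In this assay a moderate step towards a higher number, meaning a weaker inhibitor, is expected. The estimated step is a 1.8-fold higher number from compound 2 to compound 4 (0.25 log units; within the scatter) and remains uncertain. For compound 4 the expected value is 30000 nM within an estimated range from 10000 nM to 90000 nM in this test.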

Compound 4, half-maximal inhibitory concentration: 17500 nM
The estimate for compound 4 lay 1.7-fold (0.23 log units) above the measured number; low and high end bracket the measured number.
By their numbers in this assay, from the lowest: compound 1; then compound 3; then compounds 2 and 4 (each within the scatter of the next).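

In this assay, among these compounds, the replacement gives a 1.0-fold higher number from compound 2 to compound 4 (0.01 log units; within the scatter) and thus stays within the scatter, the first comparison in this set that isolates a single change. On the acetylated compound 2, therefore, hydrogen can stand in place of dodecyl, on a saturated chain carbon, three bonds along the chain from an oxygen next to a carbonyl group, with no measurable consequence in this test. The 12 carbon atoms of that group thus make no detectable contribution to the reading in this pair, and no supporting measurement accounts for this result.

The compounds shown leave open whether the same replacement would be equally silent in compound 1, which carries free hydroxyl groups on its sugar, as no pair tests the change there. They also leave open what a group of another kind would do in this place, such as a primary amine or a carboxylic acid, or a chain of intermediate length such as hexyl.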